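This account rests on a few compounds, and the source may have more. Where it says the series, first, only, none or still open, it means among the compounds named here.

Of the compounds shown here, three sharing one core have been read so far in a functional assay on MCF7 cells (Homo sapiens) for antiproliferative activity, read by MTT assay, with a stated time of 72 h (on this read-out higher numbers stand for weaker inhibition and lower numbers for stronger inhibition), on this scale. Compound 1 `C/C(=N\NC(=O)c1cccc(S(=O)(=O)N2CCOCC2)c1)c1cccc(N)c1` gives > 100000 nM as a limit of the assay, not a number. Compound 3 `C/C(=N\NC(=O)c1cccc(S(=O)(=O)N2CCOCC2)c1)c1cccc(O)c1` gives > 100000 nM and this too is only a limit, so compound 3 stands at the limit of > 100000 nM in this assay, at which 2 of the 3 values shown sit, with no number of its own. Compound 2 `C/C(=N\NC(=O)c1cccc(S(=O)(=O)N2CCOCC2)c1)c1ccccc1O` alone gives a measured value, 5400 nM in the same read-out. Its steps are large: an at least 18-fold lower number from compound 1 to compound 2 (1.26 log units; beyond the scatter) on one side and an at least 18-fold higher number from compound 2 to compound 3 (1.26 log units; beyond the scatter) on the other, while a step that the two limits leave unreadable from compound 1 to compound 3 adds nothing here.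

Compound 4 `C/C(=N\NC(=O)c1cccc(S(=O)(=O)N2CCOCC2)c1)c1cc(F)ccc1O` takes 5-fluoro-2-hydroxyphenyl in place of 3-hydroxyphenyl on a carbon with a double bond to nitrogen. The change in full is 5-fluoro-2-hydroxyphenyl in place of 3-hydroxyphenyl on a carbon with a double bond to nitrogen and its entering group carries the 2-hydroxyphenyl pattern found in compound 2. Going by the values given here, the fluoro group has no counterpart among the measured compounds. Reading an at least 18-fold higher number from compound 2 to compound 3 (1.26 log units; beyond the scatter) in reverse, a large fall in the number is expected in this assay for compound 4, to a level near that of compound 2. The expected move is an at least 22-fold lower number from compound 3 to compound 4 (1.34 log units; beyond the scatter) in size, well beyond the scatter. Compound 4 is estimated at 4500 nM with an expected range from 1300 nM to 16000 nM in this read-out.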

Compound 4, half-maximal inhibitory concentration: 6650 nM
Compound 4: the middle estimate sits 1.5-fold (0.17 log units) below what was measured, and the stated range covers the measured number.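

In this assay, compound 4 shows that a readable antiproliferative value is not unique to compound 2: the 5-fluoro-2-hydroxyphenyl group on a carbon with a double bond to nitrogen gives an at least 15-fold lower number from compound 3 to compound 4 (1.17 log units; beyond the scatter) and an at least 15-fold lower number from compound 1 to compound 4 (1.17 log units; beyond the scatter). The fluoro in place of hydrogen on an aromatic carbon gives a 1.2-fold higher number from compound 2 to compound 4 (0.09 log units; within the scatter), so this change leaves the two compounds level within the scatter. Among the four compounds, both of those carrying the 2-hydroxyphenyl pattern give measured numbers, while those with the 3-hydroxyphenyl and 3-aminophenyl groups stay at a limit of the assay: the limit of > 100000 nM in this assay, at which 2 of the 4 values shown sit.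

The compounds shown leave open whether the hydroxy of the 2-hydroxyphenyl group can be exchanged, for example for a methoxy or an amine, with a measured value kept in this assay. They also leave open whether a chloro or a methyl in place of the fluoro would give a number that differs from those of compound 2 and compound 4 by more than the scatter.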